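Swapping bromo for iodo in a growth inhibitor

The source may report more compounds than this note shows. Statements on the series, on what has been measured and on what is new or still open speak of the compounds shown alone.

Compound 1 `Cc1ccc(NC(=O)/C=C/c2ccccc2)c(C(N)=O)c1`: 4200 nM
Compound 2 `NC(=O)c1cc(Br)ccc1NC(=O)/C=C/c1ccccc1`: 1570 nM

Both values come from a functional assay on T47D cells (Homo sapiens) for inhibition, read by sulforhodamine B assay, with a stated time of 48 h; on this read-out lower numbers stand for stronger inhibition of growth and higher numbers for weaker inhibition of growth. Compound 2 has the lower number of the two, 1570 nM, which makes it the stronger growth inhibitor so far.

The next compound, compound 3 `NC(=O)c1cc(I)ccc1NC(=O)/C=C/c1ccccc1`, keeps the shared core and changes one group: iodo in place of bromo on an aromatic carbon. The new iodo group takes the place of bromo on the same aromatic carbon, meta to a carbamoyl group.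

Going by the values given here, only one measured step bears on this change: a 2.7-fold lower number from compound 1 to compound 2 (0.43 log units; beyond the scatter). That step was modest but beyond the scatter, and it replaced methyl with bromo at this same carbon. It is thin evidence, since it is a single step and a different swap. It gives no firm reason to expect a large move, so a small further drop in this assay is the best guess, and it may well stay within the scatter. The expected step is a 1.3-fold lower number from compound 2 to compound 3 (0.10 log units; within the scatter). Compound 3 is expected to give about 1250 nM, with an estimated range of 550 nM to 2800 nM.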

Compound 3, concentration for 50% growth inhibition: 857 nM
Compound 3: the middle estimate sits 1.5-fold (0.16 log units) above what was measured; measured number inside the range.
By their numbers in this assay, from the lowest: compounds 3 and 2 (each within the scatter of the next); then compound 1.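

In this assay, going by these compounds alone, the swap of bromo for iodo (a 1.8-fold lower number from compound 2 to compound 3 (0.26 log units; within the scatter)) lies within the scatter, so on this carbon the two halogens cannot be told apart, and no ranking of the pair should be drawn from it. The comparison with methyl is clearer: iodo in place of methyl (a 4.9-fold lower number from compound 1 to compound 3 (0.69 log units; beyond the scatter)) lies beyond the scatter, as bromo in place of methyl did (a 2.7-fold lower number from compound 1 to compound 2 (0.43 log units; beyond the scatter)). The single earlier step now has a companion, so among these three compounds both halogens stand apart from methyl, while the gap between the two halogens does not stand out from ordinary repeat-to-repeat variation.

The compounds shown leave open whether the same holds for other groups on this carbon, such as chloro, fluoro, methoxy or an amine, and which way a carboxylic acid there would move the number. They also offer no separate measurement that could say what lies behind these differences in growth inhibition.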